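The source may hold more compounds than are shown below. What is called first, only, known or untested is meant among the compounds shown, and "the series" means these compounds.

Of the compounds shown here, three of a shared core have been measured in an ADME assay on L02 cells (Homo sapiens) for cytotoxicity, read by MTT assay, with a stated time of 24 h; a lower number here means a stronger inhibitor, a higher number a weaker inhibitor. Compound 1, `COc1cc(/C=C2\CN(C)C/C(=C\c3ccccc3F)C2=O)cc(OC)c1OC`, gives 12100 nM in this assay. Compound 2, `CN1C/C(=C\c2ccc(C#N)cc2)C(=O)/C(=C/c2ccccc2F)C1`, gives 11000 nM, and compound 3, `COc1cc(/C=C2\CN(C)C/C(=C\c3ccc(Cl)c(Cl)c3)C2=O)cc(OC)c1`, gives 10600 nM. On the three numbers shown, compound 1 has the highest, yet its gap to compound 2 and its gap to compound 3 both lie within the usual scatter of this assay, so the three compounds cannot be told apart on these data. Among the measured compounds shown here, no pair among them differs in only one place, so no single step has been measured.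

Compound 4, `COc1cc(/C=C2\CN(C)C/C(=C\c3ccc(C#N)cc3)C2=O)cc(OC)c1OC`, has not yet been tested. It differs from compound 1 by 4-cyanophenyl in place of 2-fluorophenyl on a double-bonded chain carbon bound to a double-bonded ring carbon. Compound 2 already carries a 4-cyanophenyl group and sits where compound 1 and compound 3 sit, so nothing in the numbers points to a move in either direction. The step from compound 1 to compound 4 in this assay is expected to be small, a 1.1-fold lower number from compound 1 to compound 4 (0.02 log units; within the scatter), and not beyond the scatter. Compound 4 is therefore estimated at 11500 nM in this assay, with a range from 6000 nM to 22000 nM.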

Compound 4, half-maximal inhibitory concentration: 18600 nM
Beside the measured number, compound 4's estimate is 1.6-fold (0.21 log units) below it, and the stated range covers the measured number.
By their numbers in this assay, from the lowest: compounds 3, 2, 1 and 4 (each within the scatter of the next).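

In this assay, among the compounds shown here, the exchange of 2-fluorophenyl for 4-cyanophenyl on a double-bonded chain carbon bound to a double-bonded ring carbon gives a 1.5-fold higher number from compound 1 to compound 4 (0.19 log units; within the scatter), and this is the first step read at a single place. It shows that at this position, with the rest of compound 1 held fixed, the two groups cannot be told apart in this assay, even though the entering group brings one more heavy atom, a triple bond and a hydrogen-bond acceptor that the leaving group does not have. No measurement is available that would explain the size of this step.

The compounds shown leave open whether any group at this place can move the number beyond the scatter, since a single exchange between two substituted phenyl groups says little about very different ones, such as an amine, a carboxylic acid or a longer alkyl chain. They also leave open whether the same exchange would give a similar step if the group on the other side of the shared core were different.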